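The compounds below may be only part of what the source reports. "The series", "measured", "known", "first", "only" and "open" are said of these compounds alone.

Three analogues share one core and differ only in the group on the amide-type nitrogen whose other neighbour is the thiocarbonyl carbon. Compound 1 `COc1cc(SC)nc(NC(=S)NC(=O)c2c(-c3ccc(Cl)cc3Cl)noc2C)n1` gives -8.31% in a functional assay on the whole organism for inhibition, with Chenopodium ficifolium as the target, with a stated time of 72 h, tested at 10 mg/L; a higher number here means more inhibition of growth at the concentration tested, a lower number less inhibition of growth. Compound 2 `COc1cc(Cl)nc(NC(=S)NC(=O)c2c(-c3ccc(Cl)cc3Cl)noc2C)n1` gives 21.9% in this assay, and compound 3 `Cc1cc(C)nc(NC(=S)NC(=O)c2c(-c3ccc(Cl)cc3Cl)noc2C)n1` gives 16.9%. Compound 3 stands second highest of the three numbers: its nearest neighbour is compound 2, and the step of a number 5 percentage points lower from compound 2 to compound 3 (within the scatter) lies within the scatter, so no order between the two can be read; the step of a number 25.2 percentage points higher from compound 1 to compound 3 (beyond the scatter) is beyond the scatter.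

Compound 4 `COc1cc(OC)nc(NC(=S)NC(=O)c2c(-c3ccc(Cl)cc3Cl)noc2C)n1` is not yet measured. The change is 4,6-dimethoxypyrimidin-2-yl in place of 4,6-dimethylpyrimidin-2-yl on an amide-type nitrogen. Within the data shown here, no measured step replaces both methyl groups by methoxy groups. The step of a number 5 percentage points lower from compound 2 to compound 3 (within the scatter) shows that exchanging one group on this nitrogen for another need not move the number beyond the scatter, while a number 30.2 percentage points higher from compound 1 to compound 2 (beyond the scatter) shows that exchanging methylsulfanyl for chloro on an aromatic carbon can move it far. As far as these compounds go, the two measured groups that each carry one methoxy group lie on either side of compound 3, so the direction stays open. The expected step of a number 6.9 percentage points lower from compound 3 to compound 4 (within the scatter) is therefore small and within the scatter. Compound 4 is estimated at 10%, with a range from -15% to 35%.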

Compound 4, percent growth inhibition at one concentration: 30.7%
Compound 4: middle estimate off by 20.7 percentage points, on the low side; measured number inside the range.
By their numbers in this assay, from the lowest: compound 1; then compounds 3, 2 and 4 (each within the scatter of the next, the first and the last beyond it).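

In this assay, the step of a number 13.8 percentage points higher from compound 3 to compound 4 (beyond the scatter) shows that exchanging 4,6-dimethylpyrimidin-2-yl for 4,6-dimethoxypyrimidin-2-yl on the amide-type nitrogen can move the number beyond the scatter, which the step of a number 5 percentage points lower from compound 2 to compound 3 (within the scatter) did not show for the exchange of the 4-chloro-6-methoxypyrimidin-2-yl group. With the second methoxy group in place, the step of a number 39 percentage points higher from compound 1 to compound 4 (beyond the scatter) sets the exchange of methylsulfanyl for methoxy on an aromatic carbon beside the earlier chloro exchange as a second change from compound 1 that goes beyond the scatter, while the step of a number 8.8 percentage points higher from compound 2 to compound 4 (within the scatter) leaves chloro and methoxy on that carbon without an order. No measurement other than these growth-inhibition numbers bears on the result.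

As far as these compounds go, whether an ethoxy group or an amine such as dimethylamino on the aromatic carbon would keep the number near that of compound 4 at 30.7% stays open. Also open, from the compounds shown here alone, is whether the same ranking of the four compounds would hold in this assay at other concentrations, since each number here comes from a single concentration.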